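The compounds below may be only part of what the source reports. "The series", "measured", "known", "first", "only" and "open" are said of these compounds alone.

In an ADME assay (liver) for metabolic stability, with Liver microsome (Homo sapiens) as the target, using microsomes and NADPH, with a stated time of 30 min, tested at 1 uM (on this read-out lower numbers stand for slow clearance and higher numbers for fast clearance), three compounds sharing one core have been measured. For compound 1 `Nc1ccc(S(=O)(=O)N2CCN(c3ncc(C(O)(C(F)(F)F)C(F)(F)F)cc3C#CC3CC3)CC2)cn1`, the assay reports only a limit, < 14 mL.min-1.g-1. Compound 2 `Nc1ccc(S(=O)(=O)N2CCN(c3ncc(C(O)(C(F)(F)F)C(F)(F)F)cc3-c3cccc(F)c3)CC2)cn1` gives 25 mL.min-1.g-1, and compound 3 `COc1ccc(-c2cc(C(O)(C(F)(F)F)C(F)(F)F)cnc2N2CCN(S(=O)(=O)c3ccc(N)nc3)CC2)cn1` gives 25 mL.min-1.g-1, so compound 3 stands level with compound 2.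

Compound 4 `COc1cncc(-c2cc(C(O)(C(F)(F)F)C(F)(F)F)cnc2N2CCN(S(=O)(=O)c3ccc(N)nc3)CC2)c1` has the same atoms as compound 3, joined differently: 5-methoxypyridin-3-yl in place of 6-methoxypyridin-3-yl on an aromatic carbon. In words, 5-methoxypyridin-3-yl stands in place of 6-methoxypyridin-3-yl on an aromatic carbon. Within the data shown here, no measured step moves the methoxy group in this way. The closest guide is no change at the digits printed from compound 2 to compound 3 (within the scatter), a swap of one aromatic group for another that stays within the scatter. Two other steps replace 2-cyclopropylethynyl, an at least 1.7-fold higher number from compound 1 to compound 2 (0.25 log units; that floor lies within the scatter) and an at least 1.7-fold higher number from compound 1 to compound 3 (0.25 log units; that floor lies within the scatter), and they too show no change beyond the scatter. No step beyond the scatter is therefore expected in this assay, in either direction.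

The expected step is no change at the digits printed from compound 3 to compound 4 (within the scatter). For compound 4, the estimated value is 25 mL.min-1.g-1, with an expected range from 14 mL.min-1.g-1 to 45 mL.min-1.g-1.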

Compound 4, intrinsic clearance in microsomes: 44 mL.min-1.g-1
Beside the measured number, compound 4's estimate is 1.8-fold (0.25 log units) below it; the range from low to high includes it.
By their numbers in this assay, from the lowest: compounds 2, 3 and 4 (each within the scatter of the next). At a limit, below all of these: compound 1.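

In this assay, joining the same atoms differently, with 5-methoxypyridin-3-yl in place of 6-methoxypyridin-3-yl, gives a 1.8-fold higher number from compound 3 to compound 4 (0.25 log units; within the scatter), and the swap from 3-fluorophenyl gives a 1.8-fold higher number from compound 2 to compound 4 (0.25 log units; within the scatter), so neither change is resolved from the usual spread of repeat measurements. Replacing 2-cyclopropylethynyl with 5-methoxypyridin-3-yl gives an at least 3.1-fold higher number from compound 1 to compound 4 (0.49 log units; beyond the scatter), which, unlike the two earlier steps away from that group, clears the scatter and shows that the group at this position can matter for clearance. Compound 1 is reported only as a limit, not as a number: the limit of < 14 mL.min-1.g-1 in this assay, at which 1 of the 4 values shown sits.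

Only one alkyne is shown here, so another alkyne such as propynyl might sit close to compound 1 or close to the aromatic groups. Going by these compounds, a plain pyridin-3-yl without its methoxy group, or a morpholine at this position, also remains open.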